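The source may hold more compounds than are shown below. What is called first, only, known or untested is meant among the compounds shown, and "the series" means these compounds.

Compound 1 `O=C(CCl)NC(=O)Nc1ccc(C2CCCCC2)cc1`: 900 nM
Compound 2 `O=C(CCl)NC(=O)Nc1ccc(OC2CCCCC2)cc1`: 5000 nM

Of the compounds shown here, two have been measured in a functional assay on M21 cells (Homo sapiens) for inhibition, read by sulforhodamine B assay, with a stated time of 48 h; a higher number here means a weaker inhibitor of growth, a lower number a stronger inhibitor of growth. Compound 1 gives 900 nM in this assay, and compound 2 gives 5000 nM. Compound 2 therefore stands at the highest of the two numbers, its nearest neighbour being compound 1, from which it is separated by a 5.6-fold higher number from compound 1 to compound 2 (0.74 log units; beyond the scatter), a change that came with cyclohexyloxy in place of cyclohexyl on an aromatic carbon.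

The step under consideration leads from compound 2 to compound 3 `O=C(CCl)NC(=O)Nc1ccc(OCc2ccccc2)cc1`. The change is benzyl in place of cyclohexyl on an oxygen on an aromatic ring. For the measured compounds named here, only one measured step exists, and it concerns a different change: the insertion of the oxygen between the ring and the cyclohexyl, not the exchange of the group on that oxygen. Going by the values given here, no measured pair speaks directly to replacing a saturated ring by an aromatic one at this position, so the expectation rests on compound 2 alone as the closest reference. The step from compound 2 to compound 3 is expected to be about no change at the digits printed from compound 2 to compound 3 (within the scatter), that is, no clear movement beyond the scatter in either direction. Compound 3 is accordingly estimated at 5000 nM, with a range from 2000 nM to 15000 nM.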

Compound 3, concentration for 50% growth inhibition: 5100 nM
Estimate against measurement, compound 3: 1.0-fold (0.01 log units) below; the range from low to high includes it.
By their numbers in this assay, from the lowest: compound 1; then compounds 2 and 3 (each within the scatter of the next).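

In this assay, benzyl in place of cyclohexyl on an oxygen on an aromatic ring gives a 1.0-fold higher number from compound 2 to compound 3 (0.01 log units; within the scatter), so at this position a six-membered non-aromatic ring of carbon only and a six-membered aromatic ring of carbon only cannot be told apart. The earlier step, a 5.6-fold higher number from compound 1 to compound 2 (0.74 log units; beyond the scatter), concerned the oxygen itself and said nothing about the group it carries; this step adds that, with the oxygen in place, the exchange of this saturated ring for benzyl leaves the reading within the scatter. Nothing in the data shown accounts for the two groups reading alike.

Going by these compounds, whether this tolerance extends to a cyclohexylmethyl or phenethyl group on that oxygen, or to a chain ending in an amine or a carboxylic acid, stays open. Also open, on these data alone, is whether benzyl would match cyclohexyl when it sits directly on the aromatic carbon, as cyclohexyl does in compound 1, so the two compounds with the oxygen speak only for groups carried on that oxygen.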